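The source may report more compounds than this note shows. Statements on the series, on what has been measured and on what is new or still open speak of the compounds shown alone.

Measured compounds and their values in an ADME assay on HEK293 cells (Homo sapiens) for cytotoxicity, read by CCK-8 assay and cell counting, with a stated time of 2 days; a lower number here means a stronger inhibitor, a higher number a weaker inhibitor:

compound 1, `Oc1cccc(-c2cc(-c3cccs3)nc(-c3ccccc3Cl)c2)c1`, 2600 nM
compound 2, `Oc1cccc(-c2cc(-c3ccccc3)nc(-c3ccccc3Cl)c2)c1`, 1760 nM
compound 3, `Oc1cccc(-c2cc(-c3ccsc3)nc(-c3ccccc3Cl)c2)c1`, 2720 nM

The three compounds share one core and differ only in the group that sits on an aromatic carbon of the six-membered ring that holds the nitrogen. Compound 3 carries a thiophen-3-yl there, and its numbers sit close to those of the other two: a 1.0-fold higher number from compound 1 to compound 3 (0.02 log units; within the scatter) and a 1.5-fold higher number from compound 2 to compound 3 (0.19 log units; within the scatter). None of the three compounds can be set apart from the others on these numbers.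

Compound 4, `Oc1cccc(-c2cc(-c3ccco3)nc(-c3ccccc3Cl)c2)c1`, is the next step from compound 3: furan-2-yl in place of thiophen-3-yl on an aromatic carbon. The measured steps that bear on this change are all exchanges of the same five-membered or six-membered aromatic group at the same place: a 1.5-fold lower number from compound 1 to compound 2 (0.17 log units; within the scatter), a 1.0-fold higher number from compound 1 to compound 3 (0.02 log units; within the scatter) and a 1.5-fold higher number from compound 2 to compound 3 (0.19 log units; within the scatter). Each of them stayed within the scatter, so an exchange of one small aromatic ring for another at this position has so far left this assay untouched.

For compound 4 the expectation is therefore no step beyond the scatter, a 1.1-fold lower number from compound 3 to compound 4 (0.04 log units; within the scatter), and an estimated value of 2500 nM, between 1300 nM and 5000 nM.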

Compound 4, half-maximal inhibitory concentration: 1860 nM
Compound 4: the middle estimate sits 1.3-fold (0.13 log units) above what was measured; measured number inside the range.
By their numbers in this assay, from the lowest: compounds 2, 4, 1 and 3 (each within the scatter of the next).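

Compound 4 brings the first ring with oxygen as its hetero atom to this place next to the ring nitrogen, and in this assay this exchange stays within the scatter against each of the three earlier groups (a 1.5-fold lower number from compound 3 to compound 4 (0.17 log units; within the scatter); a 1.1-fold higher number from compound 2 to compound 4 (0.02 log units; within the scatter); a 1.4-fold lower number from compound 1 to compound 4 (0.15 log units; within the scatter)). The set of groups that cannot be told apart in this assay now holds a phenyl, two thiophenes attached in different ways and a furan, so the earlier finding also covers a change of the hetero atom from sulfur to oxygen. Nothing available offers an explanation for this flat picture.

Going by these compounds, all four groups at this place are small aromatic rings, so it remains open whether an amine, a carboxylic acid or a longer alkyl chain there would produce a step beyond the scatter. The 3-hydroxyphenyl and 2-chlorophenyl groups are the same in all four compounds, which leaves open what replacing either of them, for example the hydroxyl with a methoxy group, would do in this assay.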